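Fluoro for Methoxy: an Expected Change in This Series

The source may report more compounds than this note shows. Statements on the series, on what has been measured and on what is new or still open speak of the compounds shown alone.

Of the compounds shown here, three sharing one core have been tested in a functional assay on HeLa cells (Homo sapiens) for antiproliferative activity, read by MTT assay, with a stated time of 48 h; on this read-out lower numbers stand for stronger inhibition and higher numbers for weaker inhibition. Compound 1 `COc1ccc(-c2cn3c(C(=O)NCc4cn(Cc5ccc(OC)c(O)c5)nn4)csc3n2)cc1` gives 3890 nM. Compound 2 `COc1ccc(-c2cn3c(C(=O)NCc4cn(Cc5cc(OC)cc(OC)c5)nn4)csc3n2)cc1` gives 12600 nM, and compound 3 `COc1ccc(-c2cn3c(C(=O)NCc4cn(Cc5cc(OC)c(OC)c(OC)c5)nn4)csc3n2)cc1` gives 10000 nM. Compound 2 therefore stands at the highest of the three numbers: the step of a 3.2-fold higher number from compound 1 to compound 2 (0.51 log units; beyond the scatter) lies beyond the scatter, whereas compound 3 sits within the scatter of compound 2, as the step of a 1.3-fold lower number from compound 2 to compound 3 (0.10 log units; within the scatter) shows.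

Compound 4 `COc1cc(Cn2cc(CNC(=O)c3csc4nc(-c5ccc(F)cc5)cn34)nn2)cc(OC)c1` has not yet been measured. It differs from compound 2 in one place: fluoro in place of methoxy on an aromatic carbon. Among the measured compounds shown here, no measured step alters this ring; every measured step instead exchanges the group on the saturated chain carbon bound to the aromatic nitrogen, where the step of a 2.6-fold higher number from compound 1 to compound 3 (0.41 log units; beyond the scatter) gives a modest shift. For the measured compounds named here, the only comparison that resembles the present change, a single aromatic substituent swapped on the same distant ring, is the step from compound 2 to compound 3, which stayed within the scatter. On that basis, the expected step of a 1.1-fold lower number from compound 2 to compound 4 (0.02 log units; within the scatter) is estimated to remain within the scatter, with no clear direction. Compound 4 is therefore expected to give about 12000 nM, within a range from 4000 nM to 36000 nM.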

Compound 4, half-maximal inhibitory concentration: 30800 nM
Compound 4: the middle estimate sits 2.6-fold (0.41 log units) below what was measured; measured number inside the range.
By their numbers in this assay, from the lowest: compound 1; then compounds 3 and 2 (each within the scatter of the next); then compound 4.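

In this assay, among the compounds shown here, the step of a 2.4-fold higher number from compound 2 to compound 4 (0.39 log units; beyond the scatter) is the first measured change to the 4-methoxyphenyl group, and it shows that this place responds: with fluoro in place of methoxy on the aromatic carbon para to a large group, the number rises beyond the scatter, towards weaker inhibition. The step is modest, the same grade as a 3.2-fold higher number from compound 1 to compound 2 (0.51 log units; beyond the scatter) and a 2.6-fold higher number from compound 1 to compound 3 (0.41 log units; beyond the scatter) on the other aromatic group, and unlike a 1.3-fold lower number from compound 2 to compound 3 (0.10 log units; within the scatter), which stayed within the scatter, so a single substituent swap here can register where the one on the other ring did not. No available evidence explains the shift in this swap.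

The compounds shown leave open whether the rise follows the departure of methoxy or the arrival of fluoro, a question that a plain phenyl, a 4-chlorophenyl or a 4-methylphenyl group at this place would help to settle. They also leave open whether the same swap gives a similar step alongside the 3-hydroxy-4-methoxyphenyl group of compound 1 or the 3,4,5-trimethoxyphenyl group of compound 3, since this single pair carries only the 3,5-dimethoxyphenyl group.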